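Chloro to Bromo on the Aryl Ether of Compound 1

The source may report more compounds than this note shows. Statements on the series, on what has been measured and on what is new or still open speak of the compounds shown alone.

Compound 1 `NC1=NC2(CCSCC2)N(OCCCOc2cccc(Cl)c2)C(N)=N1` is the stronger of the two measured compounds: in a functional assay on HL-60 cells (Homo sapiens) for antiproliferative activity, read by MTT assay, with a stated time of 72 h (a lower number here means a stronger inhibitor, a higher number a weaker inhibitor), compound 1 gives 260 nM, while compound 2 `Cc1cc(C)cc(OCCCON2C(N)=NC(N)=NC23CCOCC3)c1` gives 720 nM in this assay, a gap that lies beyond the usual scatter. Compound 3 `NC1=NC2(CCSCC2)N(OCCCOc2cccc(Br)c2)C(N)=N1` differs from compound 1 in one place only: bromo in place of chloro on an aromatic carbon. Among the measured compounds shown here, no measured pair shows this exchange, so the expected step is small, in no firm direction, and likely within the scatter; the estimated step of a 1.1-fold lower number from compound 1 to compound 3 (0.05 log units; within the scatter) reflects that. Compound 3 is expected to give about 230 nM in this assay, within a range from 100 nM to 550 nM.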

Compound 3, half-maximal inhibitory concentration: 200 nM
Estimate against measurement, compound 3: 1.2-fold (0.06 log units) above; low and high end bracket the measured number.
By their numbers in this assay, from the lowest: compounds 3 and 1 (each within the scatter of the next); then compound 2.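

In this assay, the exchange of 3-chlorophenyl for 3-bromophenyl gives a 1.3-fold lower number from compound 1 to compound 3 (0.11 log units; within the scatter) and so stays within the scatter. This is the first pair shown that differs in one place only, and it shows that this position accepts either halogen with no separable difference in the number. No measurement shown offers an explanation for this result.

The compounds shown leave open how an amine, a methoxy group or a nitrile would fare at this position. They also leave open what a longer chain to the aryl ether would do.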